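Swapping a Halogen Aryl for a Dimethoxyphenyl Group

A few compounds are considered here, and "the series" means these few. Any claim that something is new, unique, unknown or untested is made for them only; others in the source may bear on it.

Measured compounds:
- compound 1, `NS(=O)(=O)c1ccc(-n2ncc3c(=O)[nH]c(-c4ccc(Cl)cc4)nc32)cc1`: 2500 nM
- compound 2, `NS(=O)(=O)c1ccc(-n2ncc3c(=O)[nH]c(-c4ccc(Br)cc4)nc32)cc1`: 14500 nM

Of the compounds shown here, two have been measured in a functional assay on MCF7 cells (Homo sapiens) for cytotoxicity, read by MTT assay, with a stated time of 72 h; on this read-out lower numbers stand for stronger inhibition and higher numbers for weaker inhibition. They share a core and differ only in the group attached to an aromatic carbon of that core. Compound 1 gives 2500 nM, while compound 2 gives 14500 nM. Among the measured compounds shown here, the single measured step is a 5.8-fold higher number from compound 1 to compound 2 (0.76 log units; beyond the scatter), so compound 2 stands as the higher of the two numbers, and the gap to compound 1 is beyond the usual scatter.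

Compound 3, `COc1ccc(-c2nc3c(cnn3-c3ccc(S(N)(=O)=O)cc3)c(=O)[nH]2)cc1OC`, has not yet been measured. It differs from compound 2 by 3,4-dimethoxyphenyl in place of 4-bromophenyl on an aromatic carbon. For the measured compounds named here, no measured step involves a dimethoxyphenyl group; the only step available, the one from compound 1 to compound 2, concerns an exchange between two halogens and does not speak directly to this change. With so little to go on, the expectation can only be loose, centred near the measured range.

Compound 3 is therefore expected to show about 8000 nM in this assay, within a range from 2000 nM to 30000 nM. That estimate amounts to an expected step of a 1.8-fold lower number from compound 2 to compound 3 (0.26 log units; within the scatter).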

Compound 3, half-maximal inhibitory concentration: > 100000 nM
Compound 3 gave a limit, no number; the forecaster's own chance of this, stated with the estimate: 15%; at least 12-fold (1.09 log units) between middle value and limit.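

For compound 3, the result in this assay is a limit and not a number: the limit of > 100000 nM in this assay, at which 1 of the 3 values shown sits.

Placing 3,4-dimethoxyphenyl in place of 4-bromophenyl on this aromatic carbon, between two ring nitrogen atoms, gives an at least 6.8-fold higher number from compound 2 to compound 3 (0.83 log units; beyond the scatter), and placing it in place of 4-chlorophenyl gives an at least 40-fold higher number from compound 1 to compound 3 (1.60 log units; beyond the scatter). The earlier pair showed only that changing one halogen on the phenyl ring can shift the read-out, whereas these steps show that a change in the substituents on that ring can weaken cytotoxicity much further, so that among these three compounds only the two halogen-bearing groups give a measured number.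

The compounds shown leave open whether the weakening belongs to the methoxy group at one ring position, at the other, or to the two together, and a 4-methoxyphenyl or 3-methoxyphenyl group would help to separate these cases. As far as these compounds go, how a plain phenyl group or a 4-aminophenyl group would behave at this position also remains open, as does the true size of both new steps, since compound 3 has only a limit.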